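A few compounds are considered here, and "the series" means these few. Any claim that something is new, unique, unknown or untested is made for them only; others in the source may bear on it.

Series measured in a functional assay on SK-N-SH cells (Homo sapiens) for cytotoxicity, read by MTT assay, with a stated time of 24 h; a lower number here means a stronger inhibitor, a higher number a weaker inhibitor:
- compound 1 `C/C(=N\NC(=O)/C(C#N)=C/c1ccc(O)cc1)c1c(O)c2ccc(O)cc2oc1=O`: 8120 nM
- compound 2 `COc1ccc(/C=C(\C#N)C(=O)N/N=C(\C)c2c(O)c3ccc(O)cc3oc2=O)cc1OC`: 21500 nM
- compound 3 `COc1ccc(/C=C(\C#N)C(=O)N/N=C(\C)c2c(O)c3ccc(O)cc3oc2=O)cc1`: 9460 nM

Compound 3 cannot be separated from compound 1, with a 1.2-fold higher number from compound 1 to compound 3 (0.07 log units; within the scatter), and it stands clear of compound 2, with a 2.3-fold lower number from compound 2 to compound 3 (0.36 log units; beyond the scatter). Next is compound 4 `C/C(=N\NC(=O)/C(C#N)=C/c1ccc([N+](=O)[O-])cc1)c1c(O)c2ccc(O)cc2oc1=O`, with nitro in place of methoxy on an aromatic carbon, para to a large group (nitro in place of methoxy on an aromatic carbon). Going by the values given here, no compound measured so far carries nitro, so the precedents are indirect. Methyl in place of hydrogen on the oxygen gave a 1.2-fold higher number from compound 1 to compound 3 (0.07 log units; within the scatter), and hydrogen in place of methoxy gave a 2.3-fold lower number from compound 2 to compound 3 (0.36 log units; beyond the scatter). Both steps are small, so no step beyond the scatter is expected in this assay, and no direction is favoured with confidence. The estimated step is a 1.1-fold lower number from compound 3 to compound 4 (0.05 log units; within the scatter). For compound 4 the expected value is 8500 nM, with an estimated range of 3500 nM to 20000 nM.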

Compound 4, half-maximal inhibitory concentration: 10300 nM
Estimate against measurement, compound 4: 1.2-fold (0.08 log units) below; the measured number falls inside the stated range.
By their numbers in this assay, from the lowest: compounds 1, 3 and 4 (each within the scatter of the next); then compound 2.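

In this assay, 4-nitrophenyl in place of 4-methoxyphenyl (a 1.1-fold higher number from compound 3 to compound 4 (0.04 log units; within the scatter)) and nitro in place of hydroxy (a 1.3-fold higher number from compound 1 to compound 4 (0.10 log units; within the scatter)) both stay within the scatter, so three different single groups at this place on the ring cannot be separated. 4-nitrophenyl in place of 3,4-dimethoxyphenyl (a 2.1-fold lower number from compound 2 to compound 4 (0.32 log units; beyond the scatter)) leaves compound 2 as the only one of the four that stands apart. Nothing available explains either result.

As far as these compounds go, whether an amine or a carboxylic acid here would shift the number remains open. So does whether the higher number of compound 2 is specific to 3,4-dimethoxyphenyl or would recur with 3,4-dichlorophenyl.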